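Chloro-to-hydrogen step in a fused-core series

The source may hold more compounds than are shown below. What is called first, only, known or untested is meant among the compounds shown, and "the series" means these compounds.

Compound 1 `ClCc1cccc(Cn2cnc3c(Cl)ncnc32)c1`, compound 2 `ClCc1ccc(Cn2cnc3nc(Cl)nc(Cl)c32)cc1` and compound 3 `ClCc1cccc(Cn2cnc3c(Cl)nc(Cl)nc32)c1` belong to one series and were tested in a functional assay on HCC 2998 cells (Homo sapiens) for cytotoxicity, read by sulforhodamine B assay, with a stated time of 48 h; on this read-out lower numbers stand for stronger inhibition of growth and higher numbers for weaker inhibition of growth. Compound 1 gives 1730 nM, compound 2 gives 3800 nM and compound 3 gives 3160 nM in this assay. The change from compound 3 to compound 1 is hydrogen in place of chloro on an aromatic carbon; it produced a 1.8-fold lower number from compound 3 to compound 1 (0.26 log units; within the scatter). The difference between the core of compound 2 and the core of compound 3 is not broken down here. Against compound 3 the value of compound 2 lies within the scatter; against compound 1 it lies beyond it.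

Compound 4 `ClCc1ccc(Cn2cnc3ncnc(Cl)c32)cc1` has not yet been measured. It differs from compound 2 by hydrogen in place of chloro on an aromatic carbon. The surroundings of the place are described in identical words for both pairs, so this is taken as the same change as that from compound 3 to compound 1. For compound 4 the expected step in this assay is a 1.7-fold lower number from compound 2 to compound 4 (0.24 log units; within the scatter). For the measured compounds named here, this rests on the single measured instance, a 1.8-fold lower number from compound 3 to compound 1 (0.26 log units; within the scatter), which itself lay within the scatter, so only a modest move toward a lower number is expected and the uncertainty is wide. Compound 4 is therefore estimated at 2200 nM in this assay, with an expected range from 1100 nM to 4500 nM.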

Compound 4, concentration for total growth inhibition: 2880 nM
Beside the measured number, compound 4's estimate is 1.3-fold (0.12 log units) below it; the measured number falls inside the stated range.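

In this assay the same replacement of chloro by hydrogen on an aromatic carbon, between two ring nitrogen atoms, was read on a second core, giving a 1.3-fold lower number from compound 2 to compound 4 (0.12 log units; within the scatter). The steps on the two cores do not differ, so in this small set the change carries from one core to the other without a detectable shift in its size, and the evidence for that is this comparison: the same change on two cores in this assay, a 1.8-fold lower number (0.26 log units; within the scatter) from compound 3 to compound 1 and a 1.3-fold lower number (0.12 log units; within the scatter) from compound 2 to compound 4, 1.4-fold (0.14 log units) apart, within the scatter of two such steps

Neither step lies beyond the scatter, however, so the agreement shows only that this chloro can give way to hydrogen on either core without a clear change in the read-out; it does not establish a real effect of the change in either direction. Two pairs, both read on a single cell line, also say nothing about how the change behaves on any core outside this series.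

The compounds shown leave open whether an amine or a methoxy group in place of that chloro would move the number beyond the scatter, since only chloro and hydrogen appear there. They also leave open what happens when the chloromethyl group gives way to a hydroxymethyl group or a longer chain, as that group is the same in all four compounds.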